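Swapping a methyl for methoxy on the phenyl ring

This account rests on a few compounds, and the source may have more. Where it says the series, first, only, none or still open, it means among the compounds named here.

Of the compounds shown here, two sharing one core have been measured in a functional assay on A549 cells (Homo sapiens) for inhibition, read by MTT assay, with a stated time of 48 h; a lower number here means a stronger inhibitor, a higher number a weaker inhibitor. Compound 1, `Cn1cc(NC(=O)c2cccc(NS(=O)(=O)c3ccccc3)c2)cn1`, reaches only the limit of this assay, giving > 100000 nM, which is not a number but a limit (the limit of > 100000 nM in this assay, at which 1 of the 2 values shown sits). Compound 2, `Cc1ccc(-n2cc(NC(=O)c3cccc(NS(=O)(=O)c4ccccc4)c3)cn2)cc1`, gives 18900 nM in this assay, the only number shown among the two. For the measured compounds named here, the one measured step, an at least 5.2-fold lower number from compound 1 to compound 2 (0.72 log units; beyond the scatter), comes from replacing a methyl with a 4-methylphenyl on the aromatic nitrogen.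

Compound 3, `COc1ccc(-n2cc(NC(=O)c3cccc(NS(=O)(=O)c4ccccc4)c3)cn2)cc1`, differs from compound 2 by methoxy in place of methyl on an aromatic carbon. Going by the values given here, no measured step involves a methyl-to-methoxy exchange, so the one step available does not bear directly on it; the aryl group stays in place, and only its substituent changes. The expectation is therefore a step within the scatter, with no clear direction. Compound 3 is estimated at 16000 nM, between 5000 nM and 50000 nM, meaning an expected step of a 1.2-fold lower number from compound 2 to compound 3 (0.07 log units; within the scatter).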

Compound 3, half-maximal inhibitory concentration: 76800 nM
The estimate for compound 3 lay 4.8-fold (0.68 log units) below the measured number; the measured number lies above the stated range.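

The substituent at the far end of the aryl group clearly matters, which the earlier step from methyl to 4-methylphenyl could not show. In this assay, methoxy in place of methyl, on the aromatic carbon para to a large group, gives a 4.1-fold higher number from compound 2 to compound 3 (0.61 log units; beyond the scatter), so having an aryl group on the aromatic nitrogen does not by itself secure the gain seen with compound 2. Set against compound 1, the 4-methoxyphenyl group gives an at least 1.3-fold lower number from compound 1 to compound 3 (0.11 log units; that floor lies within the scatter), and this step is only a floor, so no gain for compound 3 can be shown, since the value of compound 1 is a limit and not a number: the limit of > 100000 nM in this assay, at which 1 of the 3 values shown sits.

A single pair cannot say what about methoxy lies behind this change. Also open, from the compounds shown here alone, is how this assay would read with a chlorine, an amine or a carboxylic acid at this place.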